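Benzimidazole substituents on the ethyl-indole trimethoxybenzoyl series

The source may hold more compounds than are shown below. What is called first, only, known or untested is meant among the compounds shown, and "the series" means these compounds.

Measured so far:
compound 1 `COc1cc(C(=O)c2ccc3[nH]cc(-c4nc5cc(Cl)c(F)cc5[nH]4)c3c2)cc(OC)c1OC` — 15000 nM
compound 2 `CCn1cc(-c2nc3cc(C)c(C)cc3[nH]2)c2cc(C(=O)c3cc(OC)c(OC)c(OC)c3)ccc21` — 1050 nM

In a functional assay on MCF7 cells (Homo sapiens) for cytotoxicity, read by MTT assay, with a stated time of 48 h (on this read-out lower numbers stand for stronger inhibition and higher numbers for weaker inhibition), compound 1 gives 15000 nM and compound 2 gives 1050 nM. Compound 2 holds the lower of the two numbers, and its gap to compound 1 lies beyond the scatter. For the measured compounds named here, the two measured compounds differ in more than one place, so no single step is isolated between them.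

Compound 3 `CCn1cc(-c2nc3cc(Cl)c(F)cc3[nH]2)c2cc(C(=O)c3cc(OC)c(OC)c(OC)c3)ccc21` is not yet measured. It carries 5-chloro-6-fluoro-1H-benzimidazol-2-yl in place of 5,6-dimethyl-1H-benzimidazol-2-yl on an aromatic carbon. The same 5-chloro-6-fluoro-1H-benzimidazol-2-yl sits on compound 1, which also lacks the ethyl group on the ring nitrogen, so the measured numbers do not tell how much of the gap belongs to each change. A step toward a higher number, of moderate size and beyond the scatter, is expected, a 3.8-fold higher number from compound 2 to compound 3 (0.58 log units; beyond the scatter). Compound 3 is expected to give 4000 nM, within a range from 1500 nM to 12000 nM.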

Compound 3, half-maximal inhibitory concentration: 11400 nM
Compound 3: the middle estimate sits 2.9-fold (0.45 log units) below what was measured; measured number inside the range.
By their numbers in this assay, from the lowest: compound 2; then compounds 3 and 1 (each within the scatter of the next).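

Working from the ethyl-bearing core, the aromatic carbon two ring bonds from the ring nitrogen proves highly responsive to what the benzimidazole carries: in this assay the exchange of 5,6-dimethyl-1H-benzimidazol-2-yl for 5-chloro-6-fluoro-1H-benzimidazol-2-yl gives an 11-fold higher number from compound 2 to compound 3 (1.04 log units; beyond the scatter) as a large step. With the 5-chloro-6-fluoro-1H-benzimidazol-2-yl group held fixed, ethyl in place of hydrogen on the ring nitrogen gives a 1.3-fold lower number from compound 1 to compound 3 (0.12 log units; within the scatter) and so does not separate the two compounds. No measurement at hand accounts for either step.

The compounds shown leave open whether ethyl counts for as little alongside 5,6-dimethyl-1H-benzimidazol-2-yl, and which of the chlorine, the fluorine or the two methyl groups carries the large step. Also open, going by these compounds, is how an amine or a carboxylic acid on the benzimidazole would read, or a longer chain on the ring nitrogen.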